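Methyl on the phenyl: compound 2 to compound 4

This account rests on a few compounds, and the source may have more. Where it says the series, first, only, none or still open, it means among the compounds named here.

Measured values in a functional assay on HeLa cells (Homo sapiens) for antiproliferative activity, with a stated time of 5 days; a lower number here means a stronger inhibitor, a higher number a weaker inhibitor:

compound 1 `CC1OC2(C=CC(=O)C=C2)N(c2nc(-c3cccc4ccccc34)nn2-c2ccccc2)C1=O`: 110 nM
compound 2 `O=C1C=CC2(C=C1)OCC(=O)N2c1nc(-c2cccc3ccccc23)nn1-c1ccccc1`: 70 nM
compound 3 `O=C1C=CC2(C=C1)OCC(=O)N2c1nc(-c2cccc(Cl)c2)nn1-c1ccccc1`: 45.3 nM

Compound 2 holds the second highest of these three numbers; its nearest neighbour is compound 3 at a 1.5-fold lower number from compound 2 to compound 3 (0.19 log units; within the scatter), its furthest compound 1 at a 1.6-fold lower number from compound 1 to compound 2 (0.20 log units; within the scatter), both within the scatter. Compound 4 `Cc1ccc(-n2nc(-c3cccc4ccccc34)nc2N2C(=O)COC23C=CC(=O)C=C3)cc1` differs from compound 2 by methyl in place of hydrogen on an aromatic carbon. Within the data shown here, no measured step touches this phenyl. Among the measured compounds shown here, the only methyl change measured, a 1.6-fold lower number from compound 1 to compound 2 (0.20 log units; within the scatter), sits on a saturated ring carbon and stays within the scatter, so it offers no direction. For compound 4 no step beyond the scatter is therefore expected in this assay, that is no change at the digits printed from compound 2 to compound 4 (within the scatter). Compound 4 is estimated at 70 nM, in the range 30 nM to 160 nM.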

Compound 4, half-maximal inhibitory concentration: 140 nM
Estimate against measurement, compound 4: 2.0-fold (0.30 log units) below, within the range that was stated.
By their numbers in this assay, from the lowest: compounds 3, 2, 1 and 4 (each within the scatter of the next, the first and the last beyond it).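

In this assay, among these compounds, the first reading at this phenyl is a 2.0-fold higher number from compound 2 to compound 4 (0.30 log units; within the scatter) for phenyl to 4-methylphenyl, so methyl on this aromatic carbon, para to a large group, gives no step beyond the scatter. Methyl on the saturated ring carbon, read as a 1.6-fold lower number from compound 1 to compound 2 (0.20 log units; within the scatter) in the reverse sense, likewise stays inside it. Nothing measured alongside these values bears on this step.

Open, from the compounds shown here alone, is whether an amine, a carboxylic acid or methoxy on this carbon would give a step beyond the scatter. Also open, going by these compounds, is whether 4-methylphenyl reads the same with 3-chlorophenyl in place of naphthalen-1-yl.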